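Acetyl in place of methylurea on a shared naphthalene-free core

The source may hold more compounds than are shown below. What is called first, only, known or untested is meant among the compounds shown, and "the series" means these compounds.

Measured compounds:
compound 1, `COc1ccc2cc([C@](O)(c3c[nH]cn3)C(C)C)ccc2c1`, 28 nM
compound 2, `CNC(=O)c1ccc2cc(C(O)(c3c[nH]cn3)C(C)C)ccc2c1C`, 160 nM
compound 3, `CNC(=O)Nc1ccc2cc(C(O)(c3c[nH]cn3)C(C)C)ccc2c1`, 36 nM

All three were tested in an assay on isolated protein for inhibition of steroid 17-alpha-hydroxylase/17,20 lyase (Homo sapiens); on this read-out higher numbers stand for weaker inhibition and lower numbers for stronger inhibition. Compound 3 sits second highest of the three numbers. Its closest neighbour is compound 1, whose number is lower by an amount that falls within the usual scatter of such measurements, so the two cannot be told apart. Compound 2 stands furthest away, with a higher number that lies beyond the scatter, so compound 2 is the weaker inhibitor of that pair.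

Compound 4, `CC(=O)c1ccc2cc(C(O)(c3c[nH]cn3)C(C)C)ccc2c1`, has not yet been measured. It differs from compound 3 in one place: acetyl in place of (methylcarbamoyl)amino on an aromatic carbon. The change removes both hydrogen-bond donors while keeping one acceptor.

For the measured compounds named here, no step between measured compounds addresses this kind of change, so the expectation rests on the spread of the three numbers. With compound 3 giving 36 nM and compound 1 giving 28 nM, the step of a 1.4-fold higher number from compound 3 to compound 4 (0.14 log units; within the scatter) is expected to be small, likely no larger than the scatter, with a mild lean toward a higher number. Compound 4 is therefore estimated at 50 nM, within a range from 15 nM to 200 nM.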

Compound 4, half-maximal inhibitory concentration: 28 nM
Compound 4: middle estimate off by 1.8-fold (0.25 log units), on the high side; low and high end bracket the measured number.
By their numbers in this assay, from the lowest: compounds 1, 4 and 3 (each within the scatter of the next); then compound 2.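

In this assay, putting acetyl in place of (methylcarbamoyl)amino on this aromatic carbon gives a 1.3-fold lower number from compound 3 to compound 4 (0.11 log units; within the scatter), so the two compounds cannot be told apart. For the compounds shown here, this is the first direct comparison at this position: the group that leaves has 5 heavy atoms and 2 hydrogen-bond donors, the acetyl that enters has 3 heavy atoms and 0 donors, and each has 1 hydrogen-bond acceptor, so for this pair on the shared core, the donors and the extra heavy atoms are not required to keep the number in this range. Nothing measured here explains the match between the two groups.

On these data alone, whether an amine, a carboxylic acid or a longer chain on the same aromatic carbon would also give a number close to those of compound 3 and compound 4 remains open. Compound 2 differs from compound 4 in more than one place, so these compounds cannot show which of its differences goes with its higher number, and any link to a single group cannot be read from this set.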